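Piperidine nitrogen substituent swap on a GIP receptor agonist scaffold

A few compounds are considered here, and "the series" means these few. Any claim that something is new, unique, unknown or untested is made for them only; others in the source may bear on it.

Compound 2 `CS(=O)(=O)c1cnc(O[C@H]2CC[C@H](OC3CCN(CC4(C(F)(F)F)CCCC4)CC3)CC2)cn1` and compound 1 `CS(=O)(=O)c1cnc(O[C@H]2CC[C@H](OC3CCN(C(=O)OC4CCOC4)CC3)CC2)cn1` share a core and differ only in the group on the ring amine nitrogen. In a functional assay on isolated protein for agonist activity at Glucose-dependent insulinotropic receptor (Homo sapiens), read by HTRF and cAMP accumulation (on this read-out higher numbers stand for an effect only at larger amounts of compound and lower numbers for an effect already at smaller amounts), compound 1 gives 427 nM, while compound 2 gives 48.8 nM, and the step of an 8.8-fold lower number from compound 1 to compound 2 (0.94 log units; beyond the scatter) makes compound 2 the lower of the two numbers recorded in this assay.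

Compound 3 `CC(C)c1noc(CN2CCC(O[C@H]3CC[C@H](Oc4cnc(S(C)(=O)=O)cn4)CC3)CC2)n1` keeps the core of compound 2 and alters the same region: a group of 8 heavy atoms (5 carbon, 2 nitrogen, 1 oxygen; one five-membered aromatic ring with 3 hetero atoms) in place of a group of 9 heavy atoms (6 carbon, 3 fluorine; one five-membered non-aromatic ring of carbon only), on a saturated chain carbon bound to an amine nitrogen in a ring. Among the measured compounds shown here, the only measured step touching this region is the one from compound 1 to compound 2, which was modest and involved a different kind of exchange, so it gives limited guidance on whether an aromatic heterocycle in place of a carbocycle here will shift the number. The two measured compounds show that changes at this position can move this assay beyond the scatter, in either direction in principle.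

The expectation for compound 3 is therefore a step of a 1.8-fold higher number from compound 2 to compound 3 (0.27 log units; within the scatter), a slight rise that stays within the scatter, with an estimated value of 90 nM and a range from 30 nM to 300 nM.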

Compound 3, half-maximal effective concentration: 14 nM
The estimate for compound 3 lay 6.4-fold (0.81 log units) above the measured number; the measured number lies below the stated range.
By their numbers in this assay, from the lowest: compound 3; then compound 2; then compound 1.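

In this assay, the 3-isopropyl-1,2,4-oxadiazol-5-yl group gives a 3.5-fold lower number from compound 2 to compound 3 (0.54 log units; beyond the scatter) when it replaces the fluorinated carbocyclic group on the saturated chain carbon bound to the ring amine nitrogen, showing that this place accepts a five-membered aromatic ring with 3 hetero atoms and that the number can fall further from there. Set against the ((oxolan-3-yl)oxy)carbonyl group, (3-isopropyl-1,2,4-oxadiazol-5-yl)methyl gives a 31-fold lower number from compound 1 to compound 3 (1.48 log units; beyond the scatter) and is the largest step among these three compounds, so both groups attached to the amine nitrogen through a saturated chain carbon give lower numbers than the carbonyl-linked group, with no compound here going against that. Nothing available explains why the numbers move in this way.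

The compounds shown leave open whether the lower number goes with the oxadiazole ring itself or with its isopropyl group. As far as these compounds go, a phenyl ring or a 1,3,4-oxadiazole on the same carbon, or a tert-butyl group or a carboxylic acid in place of the isopropyl group, would separate these two parts, and their effect remains unknown here.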